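This account rests on a few compounds, and the source may have more. Where it says the series, first, only, none or still open, it means among the compounds named here.

Compound 1 `Cc1ncnc2c1c(I)cn2[C@@H]1O[C@H](CO)[C@@H](O)[C@H]1O` gives 5480 nM in a functional assay on CCRF-CEM cells (Homo sapiens), read by MTT assay, with a stated time of 72 h; a higher number here means a weaker inhibitor, a lower number a stronger inhibitor. In this assay compound 2 `Cc1ncnc2c1c(-c1ccoc1)cn2[C@@H]1O[C@H](CO)[C@@H](O)[C@H]1O` gives only a limit, > 20000 nM. As far as these compounds go, the change between them, (furan-3-yl in place of iodo on an aromatic carbon), made a step of an at least 3.6-fold higher number from compound 1 to compound 2 (0.56 log units; beyond the scatter); because one end of that step is the limit of > 20000 nM in this assay, at which 1 of the 3 values shown sits, its full size stays open. Compound 3 `Cc1nc(N)c2c(I)cn([C@@H]3O[C@H](CO)[C@@H](O)[C@H]3O)c2n1` gives 9030 nM in this assay, a value that lies within the scatter of compound 1. The difference between the cores of compound 1 and compound 3 is not broken down here. Compound 4 `Cc1nc(N)c2c(-c3ccoc3)cn([C@@H]3O[C@H](CO)[C@@H](O)[C@H]3O)c2n1` carries the same change on the core of compound 3, (furan-3-yl in place of iodo on an aromatic carbon). Resting on an at least 3.6-fold higher number from compound 1 to compound 2 (0.56 log units; beyond the scatter), the expected step is a 4.4-fold higher number from compound 3 to compound 4 (0.65 log units; beyond the scatter), likely again to the limit. Compound 4 is estimated at 40000 nM, between 15000 nM and 120000 nM.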

Compound 4, half-maximal inhibitory concentration: > 100000 nM
Compound 4: a limit, no number; the forecaster's own chance of this, stated with the estimate: 70%; at least 2.5-fold (0.39 log units) between middle value and limit.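

In this assay compound 4 gives > 100000 nM, which is a limit and not a number. Furan-3-yl in place of iodo on an aromatic carbon gives an at least 11-fold higher number from compound 3 to compound 4 (1.04 log units; beyond the scatter), so the change goes the same way on both cores: the same change on two cores in this assay, an at least 3.6-fold higher number (0.56 log units; beyond the scatter) from compound 1 to compound 2 and an at least 11-fold higher number (1.04 log units; beyond the scatter) from compound 3 to compound 4; the limit leaves it open whether they differ This shows that the loss carries over from one core to the other, but not how large it is on either core, nor whether the core alters its size.

The compounds shown leave open whether any other group at this place, such as an amine, a nitrile or a methyl, would hold the values of the iodo compounds. As far as these compounds go, it also remains open whether a furan-3-yl compound has any measurable value.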